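This account rests on a few compounds, and the source may have more. Where it says the series, first, only, none or still open, it means among the compounds named here.

Of the compounds shown here, three have been measured so far in a functional assay on HBL-100 cells (Homo sapiens) for cytotoxicity, read by MTT assay, with a stated time of 72 h; a lower number here means a stronger inhibitor, a higher number a weaker inhibitor.

Compound 1 `C#CCn1cc(C(=O)NC(CC(=O)Nc2ccccn2)c2ccccc2)c(=O)c2ccc(Cl)nc21` gives > 10000 nM, which is a limit of the assay rather than a number.
Compound 2 `C#CCn1cc(C(=O)NC(CC(=O)Nc2ccccc2)c2ccccc2)c(=O)c2ccc(Cl)nc21` gives 4000 nM.
Compound 3 `C#CCn1cc(C(=O)NC(CC(=O)Nc2ccccc2)c2ccccc2)c(=O)c2cccnc21` gives > 10000 nM, again a limit of the assay.

Compound 2 is thus the only one of the three to give an actual number; the other two sit at a limit. The step to compound 4 `C#CCn1cc(C(=O)NC(CC(=O)NC2CCCC2)c2ccccc2)c(=O)c2ccc(Cl)nc21` is this change: cyclopentyl in place of phenyl on an amide-type nitrogen. Within the data shown here, only one measured step touches the same amide nitrogen: an at least 2.5-fold lower number from compound 1 to compound 2 (0.39 log units; beyond the scatter). As far as these compounds go, that step moved a limit into a number, so its true size is unknown. The other step, an at least 2.5-fold higher number from compound 2 to compound 3 (0.39 log units; beyond the scatter), concerns a different position and went back to a limit, the one described in the limit of > 10000 nM in this assay, at which 2 of the 3 values shown sit. Among the measured compounds shown here, no measured compound carries a non-aromatic group on this nitrogen, so there is nothing to anchor the direction. The step from compound 2 to compound 4 is therefore expected to be small, a 1.5-fold higher number from compound 2 to compound 4 (0.18 log units; within the scatter), with a real chance that only a limit is reported. For compound 4 the expected value in this assay is 6000 nM, within 2000 nM to 20000 nM.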

Compound 4, half-maximal inhibitory concentration: 3200 nM
Estimate against measurement, compound 4: 1.9-fold (0.27 log units) above, and the stated range covers the measured number.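

In this assay, putting cyclopentyl in place of phenyl on this amide-type nitrogen gives a 1.3-fold lower number from compound 2 to compound 4 (0.10 log units; within the scatter), so a non-aromatic ring of carbon only serves here as well as the phenyl does. Replacing pyridin-2-yl with cyclopentyl at the same nitrogen gives an at least 3.1-fold lower number from compound 1 to compound 4 (0.49 log units; beyond the scatter), which means that both carbon-only rings, phenyl and cyclopentyl, give a number where pyridin-2-yl does not. The value of compound 1 is a limit of the assay, so the true size of that step stays unknown: the limit of > 10000 nM in this assay, at which 2 of the 4 values shown sit.

As far as these compounds go, it remains open whether a cyclohexyl ring, an open chain such as butyl, or a ring carrying an amine would hold this level at the nitrogen. From the compounds shown here alone, it is also open whether cyclopentyl would still give a number with hydrogen in place of the chloro, the change that led to a limit in compound 3.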